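A few compounds are considered here, and "the series" means these few. Any claim that something is new, unique, unknown or untested is made for them only; others in the source may bear on it.

In a functional assay on HepG2 cells (Homo sapiens) for antiproliferative activity, read by MTT assay, with a stated time of 48 h (a higher number here means a weaker inhibitor, a lower number a stronger inhibitor), compound 1 `N#CC1=C(N)Oc2c(N)cc3nc4ccccc4nc3c2C12C(=O)N(Cc1cnnn1-c1ccccc1Br)c1ccccc12` gives 38000 nM. Compound 2 `N#CC1=C(N)Oc2c(N)cc3nc4ccccc4nc3c2C12C(=O)N(Cc1cnnn1-c1ccc([N+](=O)[O-])cc1)c1ccccc12` carries 4-nitrophenyl in place of 2-bromophenyl on an aromatic nitrogen, and in this assay compound 2 gives > 50000 nM, which is a limit of the assay and not a number (the limit of > 50000 nM in this assay, at which 1 of the 2 values shown sits). The step of an at least 1.3-fold higher number from compound 1 to compound 2 (0.11 log units; that floor lies within the scatter) thus sets only a floor, and that floor lies within the scatter, so compound 2 stands at the weak end of the numbers shown. Compound 3 `N#CC1=C(N)Oc2c(N)cc3nc4ccccc4nc3c2C12C(=O)N(Cc1cnnn1-c1ccc(F)c(Cl)c1)c1ccccc12` differs from compound 2 by 3-chloro-4-fluorophenyl in place of 4-nitrophenyl on an aromatic nitrogen. Among the measured compounds shown here, the single measured step is the only guide here; it is small and gives no firm direction, so no step beyond the scatter is expected in this assay. Compound 3 is therefore expected to give 40000 nM, somewhere between 15000 nM and 120000 nM. The expected change an at least 1.2-fold lower number from compound 2 to compound 3 (0.09 log units; that floor lies within the scatter) is an estimate only, with a real chance that only a limit is reported again.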

Compound 3, half-maximal inhibitory concentration: > 50000 nM
Compound 3 was reported as a limit; the forecaster's own chance of this, stated with the estimate: 45%; middle value at least 1.2-fold (0.09 log units) from the limit.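

In this assay compound 3 gives > 50000 nM, which is again a limit of the assay and not a number. The step between compound 2 and compound 3 cannot be read, as both values are limits, so 3-chloro-4-fluorophenyl and 4-nitrophenyl cannot be ranked against each other. The one readable step is an at least 1.3-fold higher number from compound 1 to compound 3 (0.11 log units; that floor lies within the scatter), and it sets only a floor, so swapping a group with 2 hydrogen-bond acceptors for one with none on this aromatic nitrogen still leaves the compound at the same ceiling: the limit of > 50000 nM in this assay, at which 2 of the 3 values shown sit.

From the compounds shown here alone, how far past the limit compound 2 and compound 3 really lie stays open. Also open, going by these compounds, is whether a different group on this aromatic nitrogen, such as an aminophenyl, a carboxylic acid or a longer alkyl chain, would give a clearly lower number than compound 1.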